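The compounds below may be only part of what the source reports. "The series", "measured", "known", "first", "only" and "open" are said of these compounds alone.

Measured so far in a functional assay on CRL2813 cells (Homo sapiens) for cytotoxicity, read by sulforhodamine B assay, with a stated time of 5 days; on this read-out lower numbers stand for stronger inhibition and higher numbers for weaker inhibition:
compound 1 `O=C(Nc1cccc(C(F)(F)F)c1)N[C@H]1CC[C@@H](Oc2ccc(F)cc2)CC1` gives 2600 nM;
compound 2 `O=C(Nc1cccc(C(F)(F)F)c1)N[C@H]1CC[C@H](Oc2ccc(C(F)(F)F)cc2)CC1` gives 460 nM;
compound 3 `O=C(Nc1ccc(Cl)cc1)N[C@H]1CC[C@H](Oc2ccc(F)cc2)CC1` gives > 20000 nM, which is a limit of the assay rather than a number.

As far as these compounds go, compound 3 therefore stands at the limit of > 20000 nM in this assay, at which 1 of the 3 values shown sits, so its true potency is unknown beyond being weak. Compound 4 `O=C(Nc1ccccc1Cl)N[C@H]1CC[C@H](Oc2ccc(F)cc2)CC1` is not yet measured. It differs from compound 3 in one place: 2-chlorophenyl in place of 4-chlorophenyl on an amide-type nitrogen. Within the data shown here, no measured pair shows this kind of rearrangement, so the size of the step is uncertain; the expected step is a step that the limit leaves unreadable from compound 3 to compound 4, no larger than the usual scatter, with the result likely again only a limit. Compound 4 is estimated at 25000 nM, in a range from 8000 nM to 60000 nM.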

Compound 4, half-maximal inhibitory concentration: 9100 nM
For compound 4 the middle estimate is 2.7-fold (0.44 log units) above the measured one, and the stated range covers the measured number.
By their numbers in this assay, from the lowest: compound 2; then compound 1; then compound 4. At a limit, above all of these: compound 3.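

In this assay, 2-chlorophenyl in place of 4-chlorophenyl on an amide-type nitrogen gives an at least 2.1-fold lower number from compound 3 to compound 4 (0.34 log units; beyond the scatter). The two compounds hold the same atoms, so where the chlorine sits on this ring alone separates a measurable number for compound 4 from a limit for compound 3. The full size of the step stays unknown, since only one of its ends is a real number: the limit of > 20000 nM in this assay, at which 1 of the 4 values shown sits.

As far as these compounds go, it remains open whether a bromine or a methoxy group in place of that chlorine would give a lower or a higher number.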